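The compounds below may be only part of what the source reports. "The series", "measured", "known", "first", "only" and "open" are said of these compounds alone.

Working notes on the series. Going by the values given here, in a functional assay on CCRF-CEM cells (Homo sapiens) for antiproliferative activity, read by MTT assay, with a stated time of 72 h (on this read-out lower numbers stand for stronger inhibition and higher numbers for weaker inhibition), compound 1 `C=C(Br)C(=O)Nc1ccc2c(c1)/C(=C/c1cccs1)C(=O)N2` gives 35 nM and holds the lowest number measured so far. Compound 3 `C=C(Br)C(=O)Nc1ccc2c(c1)CC(=O)N2` is the nearest with 220 nM as its value, a higher number by a gap beyond the usual scatter. Compound 2 `Nc1ccc2c(c1)C(=Cc1ccsc1)C(=O)N2` reads > 10000 nM and this is a limit of the assay, not a number.

The step followed here leads from compound 1 to compound 4 `C=C(Br)C(=O)Nc1ccc2c(c1)/C(=C/c1sccc1C)C(=O)N2`. Thiophen-2-yl becomes 3-methylthiophen-2-yl methyl in place of hydrogen on an aromatic carbon and the methyl stands next to the ring atom that bears a large group and two ring bonds from the ring sulfur.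

Among the compounds with values here, no measured pair shows a change on this ring, and the expectation therefore has little to rest on. It starts from compound 1 (35 nM) and from the size of the change, a single methyl. In this assay no step beyond the scatter is expected, with only a slight lean toward a higher number. The expected step is a 1.1-fold higher number from compound 1 to compound 4 (0.06 log units; within the scatter) and it is estimated to stay within the scatter. For compound 4 the estimate is 40 nM with an expected range of (12 nM to 130 nM).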

Compound 4, half-maximal inhibitory concentration: 0.5 nM
Beside the measured number, compound 4's estimate is 80-fold (1.90 log units) above it, and the stated range ends above it.
By their numbers in this assay, from the lowest: compound 4; then compound 1; then compound 3. At a limit, above all of these: compound 2.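

In this assay, methyl in place of hydrogen on an aromatic carbon of the five-membered aromatic ring with 1 sulfur gives a 70-fold lower number from compound 1 to compound 4 (1.85 log units; beyond the scatter), a large step from the addition of a single carbon. Going by these compounds alone, this is the first pair that differs in one place, and it shows that this ring position, next to the ring atom that bears a large group and two ring bonds from the ring sulfur, is far from silent: the earlier compounds gave no reading on any change to this ring, and here a small change moves the number well beyond the scatter. Nothing at hand bears on why a single methyl here has so large an effect.

The compounds shown leave open whether this step belongs to methyl alone or would carry over to an ethyl, a methoxy or a chlorine at the same place, and whether a methyl on another carbon of this ring would give a similar step. They also leave open whether an amine or a hydroxymethyl at this place would keep the low number of compound 4.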